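Swapping Methyl for Isopropyl on Two Related Amide Cores

The compounds below may be only part of what the source reports. "The series", "measured", "known", "first", "only" and "open" are said of these compounds alone.

Measured compounds:
compound 1, `CCc1ccc(C(CCN2CCN(c3ccccc3OC)CC2)Oc2ccc(NC(=O)c3ccccc3OCCCC(=O)O)cc2)cc1`: 130 nM
compound 2, `COc1ccccc1N1CCN(CCC(Oc2ccc(NC(=O)c3ccccc3OCCCC(=O)O)cc2)c2ccc(CC(C)C)cc2)CC1`: 96 nM
compound 3, `CCc1ccc(C(CCN2CCN(c3ccccc3OC)CC2)Oc2ccc(C(=O)Nc3ccccc3OCCCC(=O)O)cc2)cc1`: 70 nM

All three were tested in an assay on isolated protein for inhibition of steroid 5-alpha-reductase (Rattus norvegicus); a higher number here means a weaker inhibitor, a lower number a stronger inhibitor. Compound 1 and compound 3 are built from the same atoms joined differently; the difference between the two cores is not broken down here. Compound 2 differs from compound 1 by a single change, (isopropyl in place of methyl on a saturated chain carbon bound to an aromatic carbon), which gave a 1.4-fold lower number from compound 1 to compound 2 (0.13 log units; within the scatter). Compound 4, `COc1ccccc1N1CCN(CCC(Oc2ccc(C(=O)Nc3ccccc3OCCCC(=O)O)cc2)c2ccc(CC(C)C)cc2)CC1`, has not yet been measured; it carries the same change on the core of compound 3, (isopropyl in place of methyl on a saturated chain carbon bound to an aromatic carbon), at the same place. Since that change made a 1.4-fold lower number from compound 1 to compound 2 (0.13 log units; within the scatter), compound 4 is expected to show a step of a 1.4-fold lower number from compound 3 to compound 4 (0.15 log units; within the scatter). In this assay compound 4 is therefore estimated at 50 nM, most likely between 25 nM and 110 nM.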

Compound 4, half-maximal inhibitory concentration: 39 nM
Beside the measured number, compound 4's estimate is 1.3-fold (0.11 log units) above it, within the range that was stated.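

In this assay, putting isopropyl in place of methyl on the core of compound 3 gave a 1.8-fold lower number from compound 3 to compound 4 (0.25 log units; within the scatter). Set beside the earlier step, the change reads alike on both cores: the same change on two cores in this assay, a 1.4-fold lower number (0.13 log units; within the scatter) from compound 1 to compound 2 and a 1.8-fold lower number (0.25 log units; within the scatter) from compound 3 to compound 4, 1.3-fold (0.12 log units) apart, within the scatter of two such steps. This shows that the change carried over to a second core without a distinct difference in step size, but it does not show that the change itself improves inhibition, since each step on its own stays within the scatter, and two cores cannot speak for the whole series.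

The compounds shown leave open whether another group at this place, such as tert-butyl or trifluoromethyl, would give a step beyond the scatter.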